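Swapping the benzylic amine for a quinolinyl amine on the shared core

This account rests on a few compounds, and the source may have more. Where it says the series, first, only, none or still open, it means among the compounds named here.

Measured compounds:
compound 1 `CC(Nc1ncnc2ccc(-c3cnn(C4CCNCC4)c3)cc12)c1c(Cl)ccc(F)c1Cl` gives 12600 nM in a functional assay on MDA-MB-231 cells (Homo sapiens) for antiproliferative activity, read by MTT assay, with a stated time of 72 h; a higher number here means a weaker inhibitor, a lower number a stronger inhibitor
compound 2 `CC(Nc1nc(N)nc2ccc(-c3cnn(C4CCNCC4)c3)cc12)c1c(Cl)ccc(F)c1Cl` gives 4480 nM in this assay

Going by the values given here, compound 1 stands at the higher of the two numbers, with compound 2 as its only neighbour; the single measured step, a 2.8-fold lower number from compound 1 to compound 2 (0.45 log units; beyond the scatter), is a change on an aromatic carbon of the core and leaves the amine-bound side chain untouched.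

Compound 3 `c1cnc2ccc(Nc3ncnc4ccc(-c5cnn(C6CCNCC6)c5)cc34)cc2c1` differs from compound 1 at that side chain: quinolin-6-yl in place of 1-(2,6-dichloro-3-fluorophenyl)ethyl on a nitrogen on an aromatic ring. Among the compounds with values here, no measured step touches this part of the structure, so the change from compound 1 to compound 3 has no precedent among the two measured compounds, and nothing in the data shows which direction it should take.

With that in mind, compound 3 is estimated to land near compound 1 in this assay, with a wide range to reflect the missing precedent, 9000 nM (from 2000 nM to 40000 nM), meaning an expected step of a 1.4-fold lower number from compound 1 to compound 3 (0.15 log units; within the scatter).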

Compound 3, half-maximal inhibitory concentration: 30300 nM
For compound 3 the middle estimate is 3.4-fold (0.53 log units) below the measured one; measured number inside the range.
By their numbers in this assay, from the lowest: compound 2; then compound 1; then compound 3.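

In this assay, going by these compounds alone, the side chain on the nitrogen on an aromatic ring proves to be a position that responds to change, which the step on the core between the earlier compounds could not show. Quinolin-6-yl in place of 1-(2,6-dichloro-3-fluorophenyl)ethyl gives a 2.4-fold higher number from compound 1 to compound 3 (0.38 log units; beyond the scatter), so this replacement moves the number up, opposite in direction to the amino change on the core. No evidence here accounts for that rise.

The compounds shown leave open whether the amino group of compound 2 would also lower the number when paired with quinolin-6-yl. They also leave open whether a plain phenyl, or a 1-phenylethyl group carrying no chlorine or fluorine, on that nitrogen would fall nearer compound 1 or compound 3.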